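A few compounds are considered here, and "the series" means these few. Any claim that something is new, unique, unknown or untested is made for them only; others in the source may bear on it.

Compound 1 `CSc1ccc(NC(=O)Nc2cc(C)nc3ccccc23)cc1` stands in an ADME assay on BJ cells (Homo sapiens) for cytotoxicity, with a stated time of 72 h (a higher number here means that more compound is needed for the effect, a lower number that less compound is needed), at > 25000 nM, which is a limit of the assay rather than a number. Compound 2 `Cc1cc(NC(=O)Nc2cnc3ccccc3c2)c2ccccc2n1` likewise gives only a limit, > 25000 nM. Within the data shown here, both values sit at the limit of > 25000 nM in this assay, at which 2 of the 2 values shown sit, so no step between measured compounds is at hand. Compound 3 `Cc1cc(NC(=O)Nc2ccc(OC(F)(F)F)cc2)c2ccccc2n1` differs from compound 1 by trifluoromethoxy in place of methylsulfanyl on an aromatic carbon. With both measured compounds at a limit, no movement beyond the usual scatter is expected in this assay for this change. Compound 3 is therefore expected at about 30000 nM, within a range of 10000 nM to 100000 nM, an expected step that the limit leaves unreadable from compound 1 to compound 3.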

Compound 3, half-maximal effective concentration: 25000 nM
Beside the measured number, compound 3's estimate is 1.2-fold (0.08 log units) above it; measured number inside the range.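

In this assay compound 3 gives a plain number, 25000 nM, the first among the compounds shown. Compound 1 gives > 25000 nM, which is a limit. Trifluoromethoxy in place of methylsulfanyl on this aromatic carbon gives a number no higher from compound 1 to compound 3 (the limit leaves the size open), so the change shows no clear effect on cytotoxicity, only that the larger group still leaves the value at the same figure as the limit. Going by these compounds, whether an amine or a carboxylic acid on this carbon would give a clearly lower value remains open.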